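This account rests on a few compounds, and the source may have more. Where it says the series, first, only, none or still open, it means among the compounds named here.

Measured in a functional assay on a cell-free system (plasma, Oryctolagus cuniculus) for inhibition of platelet-activating factor acetylhydrolase (Homo sapiens), tested at 100 nM; on this read-out lower numbers stand for less inhibition and higher numbers for more inhibition at the one concentration tested (going by the name of the read-out):
compound 1 `CCCCCCCCN(C)C(=O)Cn1cc(Cc2cnc(OC)nc2)c(=O)nc1SCc1ccc(F)cc1` gives 13%
compound 2 `CCCCCCCCN(C)C(=O)Cn1cc(Cc2cnc(OCC)nc2)c(=O)nc1SCc1ccc(F)cc1` gives 7%
compound 3 `CCCCCCCCN(C)C(=O)Cn1cc(Cc2cnc(=O)n(C)c2)c(=O)nc1SCc1ccc(F)cc1` gives 19%

Compound 4 `CCCCCCCCN(C)C(=O)Cn1cc(Cc2cnc(=O)n(CC)c2)c(=O)nc1SCc1ccc(F)cc1` has not yet been measured. The change from compound 3 to compound 4 is methyl in place of hydrogen on a saturated chain carbon bound to an aromatic nitrogen. The same change was made from compound 1 to compound 2, (methyl in place of hydrogen on a saturated chain carbon bound to an oxygen on an aromatic ring), and in this assay it made a number 6 percentage points lower from compound 1 to compound 2 (within the scatter). The two cores differ by a group of 8 heavy atoms (5 carbon, 2 nitrogen, 1 oxygen; one six-membered aromatic ring with 2 hetero atoms) in place of a group of 8 heavy atoms (5 carbon, 2 nitrogen, 1 oxygen; one six-membered aromatic ring with 2 hetero atoms), on a saturated chain carbon bound to an aromatic carbon. The places are not identical: in the measured pair the saturated chain carbon is bound to an oxygen on an aromatic ring, in the new pair to an aromatic nitrogen, so the change is the same kind of change, not the same. Among the measured compounds, a number 6 percentage points higher from compound 1 to compound 3 (within the scatter) and a number 12 percentage points higher from compound 2 to compound 3 (beyond the scatter). Because in this assay a number 6 percentage points lower from compound 1 to compound 2 (within the scatter), a similarly small step is expected from compound 3 to compound 4, namely a number 5 percentage points lower from compound 3 to compound 4 (within the scatter). Compound 4 is thus estimated at 14%, expected between 4% and 25%.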

Compound 4, a percentage reported as inhibition, at one concentration (the size of the read-out at that concentration, not a potency): 5%
Estimate against measurement, compound 4: 9 percentage points above, and the stated range covers the measured number.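

In this assay, the methyl in place of hydrogen on the chain carbon bound to the aromatic nitrogen gave a number 14 percentage points lower from compound 3 to compound 4 (beyond the scatter), and this step does not differ from the earlier one on the other core: the same change on two cores in this assay, a number 6 percentage points lower (within the scatter) from compound 1 to compound 2 and a number 14 percentage points lower (beyond the scatter) from compound 3 to compound 4, 8 percentage points apart, within the scatter of two such steps. Between the cores the readings are a number 2 percentage points lower from compound 2 to compound 4 (within the scatter) and a number 8 percentage points lower from compound 1 to compound 4 (within the scatter), so the ethyl compounds on the two cores cannot be told apart here. Within the data shown here, this shows that the change carried over without a detectable difference in these two pairs, but only one of the two steps lies beyond the scatter, and two pairs establish no general rule.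

The compounds shown leave open whether a longer chain such as propyl would continue the step. They also leave open how an amine or a carboxylic acid at this place would read.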